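Aryl replacement in a low-displacement series

The source may report more compounds than this note shows. Statements on the series, on what has been measured and on what is new or still open speak of the compounds shown alone.

All three measured compounds share one core and differ only in the group next to the ring sulfur. Compound 1 `CC(C)(C)Cc1c(-c2ccccn2)sc(N)c1C(=O)c1ccc(Cl)cc1` gives 1% in an assay on CHO cells for displacement of a labelled ligand from adenosine receptor A3 (Homo sapiens), read by scintillation counting, tested at 10 uM; on this read-out higher numbers stand for more inhibition at the one concentration tested (going by the name of the read-out) and lower numbers for less inhibition. Compound 2 `CC(C)(C)Cc1c(-c2ccc(F)cc2F)sc(N)c1C(=O)c1ccc(Cl)cc1` gives 1% in this assay, with no change at the digits printed from compound 1 to compound 2 (within the scatter). Compound 3 `CC(C)(C)Cc1c(/C=C/c2ccc(Cl)cc2)sc(N)c1C(=O)c1ccc(Cl)cc1` gives 11% in this assay, the highest of the three numbers, yet a number 10 percentage points higher from compound 1 to compound 3 (within the scatter) and a number 10 percentage points higher from compound 2 to compound 3 (within the scatter) both sit within the scatter, so no order among the three is established.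

Compound 4 `CC(C)(C)Cc1c(-c2ccc(Cl)c(Cl)c2)sc(N)c1C(=O)c1ccc(Cl)cc1` carries the change (3,4-dichlorophenyl in place of 2-(4-chlorophenyl)ethenyl on an aromatic carbon). The step that bears most directly on it runs the other way between these same classes of group: a number 10 percentage points higher from compound 2 to compound 3 (within the scatter), a difference within the scatter. The aryl-to-aryl step no change at the digits printed from compound 1 to compound 2 (within the scatter) likewise shows nothing beyond the scatter. Hence for compound 4 no step beyond the scatter is expected in this assay, and a number 8 percentage points lower from compound 3 to compound 4 (within the scatter) is the estimated step. Compound 4 is expected to give about 3%, within a range of -6% to 12%.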

Compound 4, a percentage reported as inhibition, at one concentration (the size of the read-out at that concentration, not a potency): 1%
Estimate against measurement, compound 4: 2 percentage points above; low and high end bracket the measured number.
By their numbers in this assay, from the lowest: compounds 1, 2, 4 and 3 (each within the scatter of the next).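

Putting 3,4-dichlorophenyl in place of 2-(4-chlorophenyl)ethenyl next to the ring sulfur removes the double bond outside the aromatic rings, and this assay shows a number 10 percentage points lower from compound 3 to compound 4 (within the scatter). For the compounds shown here, with 3,4-dichlorophenyl as a third directly attached ring at this position, the read-out gives no change at the digits printed from compound 2 to compound 4 (within the scatter) and no change at the digits printed from compound 1 to compound 4 (within the scatter), so chlorine on the phenyl ring separates no compound here from the 2,4-difluorophenyl or pyridin-2-yl analogues. No supporting data bear on these results.

Going by these compounds, whether any group at this position can lift the read-out clear of the scatter stays open, for example a carboxylic acid, a piperidine or a longer alkyl chain. The compounds shown also leave open what a change to the neopentyl, amino or (4-chlorophenyl)carbonyl group would do.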